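Aryl group change on the double-bonded nitrogen: working notes

The source may report more compounds than this note shows. Statements on the series, on what has been measured and on what is new or still open speak of the compounds shown alone.

- compound 1 `O=C1Nc2ccc(S(=O)(=O)N3CCOCC3)cc2/C1=N/c1ccc(Br)cc1`: 15300 nM
- compound 2 `O=C1Nc2ccc(S(=O)(=O)N3CCOCC3)cc2/C1=N/c1ccc(O)cc1`: 27300 nM

Among the compounds with values here, in a functional assay on HCT-116 cells (Homo sapiens) for cytotoxicity, read by sulforhodamine B assay, with a stated time of 24 h (a higher number here means a weaker inhibitor, a lower number a stronger inhibitor), compound 2 gives 27300 nM, which lies within the scatter of compound 1, the only other measured compound. Compound 3 `O=C1Nc2ccc(S(=O)(=O)N3CCOCC3)cc2/C1=N/c1cccc(C(F)(F)F)c1` carries 3-(trifluoromethyl)phenyl in place of 4-hydroxyphenyl on a double-bonded nitrogen. Within the data shown here, the one measured step bearing on this change, a 1.8-fold higher number from compound 1 to compound 2 (0.25 log units; within the scatter), stayed within the scatter. Among the measured compounds shown here, no measured compound carries trifluoromethyl, so the expectation is weak, and no shift beyond the scatter is expected in this assay. The expected step is a 1.4-fold lower number from compound 2 to compound 3 (0.14 log units; within the scatter). Compound 3 is estimated at 20000 nM, with an expected range of 8000 nM to 50000 nM.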

Compound 3, half-maximal inhibitory concentration: 15900 nM
The estimate for compound 3 lay 1.3-fold (0.10 log units) above the measured number; the range from low to high includes it.
By their numbers in this assay, from the lowest: compounds 1, 3 and 2 (each within the scatter of the next).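

In this assay, 3-(trifluoromethyl)phenyl in place of 4-hydroxyphenyl on the double-bonded nitrogen gives a 1.7-fold lower number from compound 2 to compound 3 (0.23 log units; within the scatter), and in place of 4-bromophenyl it gives a 1.0-fold higher number from compound 1 to compound 3 (0.02 log units; within the scatter). All three aryl groups at this position therefore lie within the scatter of each other, whether or not the group carries a hydrogen-bond donor. Nothing available bears on the reason for this result.

Still open, as far as these compounds go, is whether an amine or a carboxylic acid on the aryl group would shift the number beyond the scatter. The compounds shown also do not separate the identity of a substituent from its place on the ring.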